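From phenyl to 2,6-difluorophenyl on a carbonyl carbon

This account rests on a few compounds, and the source may have more. Where it says the series, first, only, none or still open, it means among the compounds named here.

Measured so far in a functional assay on NCI-H460 cells (Homo sapiens) for inhibition, read by CCK-8 assay, with a stated time of 72 h (on this read-out lower numbers stand for stronger inhibition and higher numbers for weaker inhibition), are two compounds:
- compound 1 `Nc1ccccc1NC(=O)c1ccc(CNC(=O)c2n[nH]cc2NC(=O)c2ccccc2)cc1` with 6320 nM as its value
- compound 2 `O=C(NO)c1ccc(CNC(=O)c2n[nH]cc2NC(=O)c2ccccc2F)cc1` with 23700 nM as its value

Compound 1 holds the lower of these two numbers, and so the stronger inhibition of the pair. The gap up to compound 2 lies beyond the usual scatter of repeated measurements.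

Compound 3 `Nc1ccccc1NC(=O)c1ccc(CNC(=O)c2n[nH]cc2NC(=O)c2c(F)cccc2F)cc1` has not yet been measured. It keeps the core of compound 1 and differs from it in one place (2,6-difluorophenyl in place of phenyl on a carbonyl carbon), with 2,6-difluorophenyl in place of phenyl on a carbonyl carbon.

For the measured compounds named here, no two measured compounds differ in one place only, so the data offer no measured step for this change. The starting point is compound 1 at 6320 nM in this assay, and the expectation carries real uncertainty. A modest move toward a lower number is expected, though a result within the scatter would not be surprising. The expected size of the change is a 2.1-fold lower number from compound 1 to compound 3 (0.32 log units; beyond the scatter) in this estimate. Compound 3 is estimated at 3000 nM (expected range 700 nM to 11000 nM).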

Compound 3, half-maximal inhibitory concentration: 7790 nM
Compound 3: the middle estimate sits 2.6-fold (0.41 log units) below what was measured; the measured number falls inside the stated range.
By their numbers in this assay, from the lowest: compounds 1 and 3 (each within the scatter of the next); then compound 2.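

In this assay, for the compounds shown here, placing 2,6-difluorophenyl in place of phenyl on a carbonyl carbon whose other neighbour is an amide-type nitrogen gives a 1.2-fold higher number from compound 1 to compound 3 (0.09 log units; within the scatter), the first measured step at this position. The step lies within the scatter, so compound 3 at 7790 nM and compound 1 at 6320 nM cannot be told apart on this read-out. This position therefore accepts the two added fluorine atoms with no change that this assay can separate from repeat measurement, although this single pair cannot show how the position responds to other changes. Nothing further is at hand that bears on this result.

With only this one step at the position, the compounds shown leave open whether a single fluorine on this ring, with the rest of compound 1 kept, would stay within the scatter as well. They also leave open whether a different kind of group on the same ring, such as a methoxy group, an amine or a carboxylic acid, would move the number beyond the scatter in either direction.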